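Trading a Methoxy for a Free Hydroxy on Compound 2

The compounds below may be only part of what the source reports. "The series", "measured", "known", "first", "only" and "open" are said of these compounds alone.

Compound 2 `COc1ccc([C@@H]2[C@H](Oc3ccccc3)C(=O)N2c2cc(OC)c(OC)c(OC)c2)cc1OC` carries a 3,4-dimethoxyphenyl group on a saturated ring carbon of the shared core. In a functional assay on MCF7 cells (Homo sapiens) for antiproliferative activity, read by MTT assay, with stated times of 24 h and 72 h (on this read-out lower numbers stand for stronger inhibition and higher numbers for weaker inhibition), compound 2 gives 26000 nM, the second highest of the three numbers in hand. Its nearest neighbour is compound 3 `COc1cc(N2C(=O)[C@@H](Oc3ccccc3)[C@H]2c2ccc([S+](C)[O-])cc2)cc(OC)c1OC`, which gives 20000 nM; the step of a 1.3-fold lower number from compound 2 to compound 3 (0.11 log units; within the scatter) lies within the scatter, so the two cannot be ordered. Furthest away is compound 1 `COc1cccc([C@@H]2[C@H](Oc3ccccc3)C(=O)N2c2cc(OC)c(OC)c(OC)c2)c1`, which gives 171000 nM, and the step of a 6.6-fold lower number from compound 1 to compound 2 (0.82 log units; beyond the scatter) is beyond the scatter.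

Compound 4 `COc1cc([C@@H]2[C@H](Oc3ccccc3)C(=O)N2c2cc(OC)c(OC)c(OC)c2)ccc1O` differs from compound 2 in one place: hydrogen in place of methyl on an oxygen on an aromatic ring. The measured step that bears most on this is a 6.6-fold lower number from compound 1 to compound 2 (0.82 log units; beyond the scatter), where a methoxy entering on an aromatic carbon brought a modest gain. The step of an 8.6-fold lower number from compound 1 to compound 3 (0.93 log units; beyond the scatter) was of similar size but concerned the other aromatic group. Among the compounds with values here, no measured step removes a methyl from an oxygen, so the direction of this change is not anchored by the data. He therefore expects a step from compound 2 to compound 4 that is small and most likely within the scatter, if anything a modest move toward a higher number, which in this assay means weaker inhibition: a 1.3-fold higher number from compound 2 to compound 4 (0.13 log units; within the scatter). On that basis compound 4 is estimated at 35000 nM, between 12000 nM and 100000 nM.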

Compound 4, half-maximal inhibitory concentration: 32000 nM
Beside the measured number, compound 4's estimate is 1.1-fold (0.04 log units) above it; low and high end bracket the measured number.
By their numbers in this assay, from the lowest: compounds 3, 2 and 4 (each within the scatter of the next); then compound 1.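

In this assay, within the data shown here, the first step that touches the oxygen on the aromatic ring, a 1.2-fold higher number from compound 2 to compound 4 (0.09 log units; within the scatter), stays within the scatter, so the 3,4-dimethoxyphenyl and 4-hydroxy-3-methoxyphenyl groups cannot be told apart here, and the methyl on this oxygen shows no measurable part in the number. The earlier compounds shown here showed only that a methoxy entering on an aromatic carbon went with a lower number; the new step of a 5.3-fold lower number from compound 1 to compound 4 (0.73 log units; beyond the scatter) lies beyond the scatter and shows that a hydroxy on that carbon does so as well. With a 1.6-fold higher number from compound 3 to compound 4 (0.20 log units; within the scatter) also within the scatter, compound 2, compound 3 and compound 4 cannot be ordered among themselves, while each stands beyond the scatter from compound 1.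

The compounds shown leave open whether a longer chain on this oxygen, or an amine or a carboxylic acid in place of the hydroxy, would stay within the scatter of compound 2 or move beyond it. Nothing available speaks to the cause of any of these numbers.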